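The compounds below may be only part of what the source reports. "The series", "measured", "known", "first", "only" and "open" are said of these compounds alone.

Compound 1, `CCCS(=O)(=O)Nc1ccc(F)c(C(=O)c2n[nH]c3ncc(-c4ccc(C)cc4)cc23)c1F`, in an assay for binding affinity to dual specificity mitogen-activated protein kinase kinase 4 (Homo sapiens), read by KINOMEscan, tested at 100 nM; a lower number here means a stronger effect, a higher number a weaker effect of the compound at the concentration tested: 5.4%
Compound 2, `CCCS(=O)(=O)Nc1ccc(F)c(C(=O)c2n[nH]c3ncc(-c4ccc(S(N)(=O)=O)cc4)cc23)c1F`, in this assay: 0.25%

For the measured compounds named here, compound 2 stands at the lowest of the two numbers, but the only measured step, a number 5.2 percentage points lower from compound 1 to compound 2 (within the scatter), lies within the scatter, so the two compounds are not separated. Compound 3, `CCCS(=O)(=O)Nc1ccc(F)c(C(=O)c2n[nH]c3ncc(-c4ccc(S(=O)(=O)NC(C)=O)cc4)cc23)c1F`, differs from compound 2 by acetyl in place of hydrogen on a sulfonamide nitrogen. Going by the values given here, the one step that bears on this part of the structure is a number 5.2 percentage points lower from compound 1 to compound 2 (within the scatter), and it was within the scatter. The step of a number 1.3 percentage points higher from compound 2 to compound 3 (within the scatter) is therefore expected to stay within the scatter as well. Compound 3 is estimated at 1.5%, with a range from 0.1% to 12%.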

Compound 3, a percentage reported as activity, at one concentration (the size of the read-out at that concentration, not a potency): 0.35%
For compound 3 the middle estimate is 1.2 percentage points above the measured one; measured number inside the range.
By their numbers in this assay, from the lowest: compounds 2, 3 and 1 (each within the scatter of the next).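

Acetyl on the sulfonamide nitrogen gives a number 0.1 percentage points higher from compound 2 to compound 3 (within the scatter) in this assay and so leaves the two compounds unseparated, which shows that this nitrogen can carry the added group without a readable change. Acetylsulfamoyl in place of methyl on the aromatic carbon gives a number 5.1 percentage points lower from compound 1 to compound 3 (within the scatter) and thus, like sulfamoyl, is not separated from methyl. No measurement at hand accounts for this result.

On these data alone, whether a longer chain or a benzoyl group on that nitrogen would also stay within the scatter remains open. So does whether a carboxylic acid or an amine in place of the whole group would separate from these compounds.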